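Adding a second trifluoromethyl to the terminal urea phenyl

This account rests on a few compounds, and the source may have more. Where it says the series, first, only, none or still open, it means among the compounds named here.

Measured compounds:
Compound 1 `O=C(Nc1cccc(-n2cc(-c3ccncc3)c(-c3ccc(Cl)c(O)c3)n2)c1)Nc1cc(C(F)(F)F)cc(C(F)(F)F)c1` gives 1240 nM in a functional assay on NCI-H226 cells (Homo sapiens) for inhibition, read by sulforhodamine B assay, with a stated time of 48 h; on this read-out lower numbers stand for stronger inhibition of growth and higher numbers for weaker inhibition of growth.
Compound 2 `COc1cc(-c2nn(-c3cccc(NC(=O)Nc4cccc(C(F)(F)F)c4)c3)cc2-c2ccncc2)ccc1Cl` gives 1380 nM in this assay.
Compound 3 `COc1cc(-c2nn(-c3cccc(NC(=O)Nc4ccc(Cl)c(Cl)c4)c3)cc2-c2ccncc2)ccc1Cl` gives 1350 nM in this assay.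

Compound 2 has the highest number of the three in this assay, but its neighbours sit close: compound 3 lies a 1.0-fold lower number from compound 2 to compound 3 (0.01 log units; within the scatter), and compound 1 differs from it by an amount that is also within the scatter, so no order among these three can be read from the numbers.

Compound 4 `COc1cc(-c2nn(-c3cccc(NC(=O)Nc4cc(C(F)(F)F)cc(C(F)(F)F)c4)c3)cc2-c2ccncc2)ccc1Cl` has not yet been measured. Relative to compound 2 the change is trifluoromethyl in place of hydrogen on an aromatic carbon. Among the compounds with values here, the one measured step that speaks to the terminal urea phenyl is the exchange of 3-(trifluoromethyl)phenyl for 3,4-dichlorophenyl, which gave a 1.0-fold lower number from compound 2 to compound 3 (0.01 log units; within the scatter). Compound 1 carries the same bis(trifluoromethyl)phenyl as compound 4 on a core that differs in only one other place, and its value sits within the scatter of compound 2.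

Nothing in these data points to a shift beyond the scatter, so the step from compound 2 is expected to be a 1.1-fold lower number from compound 2 to compound 4 (0.03 log units; within the scatter). Compound 4 is therefore estimated at 1300 nM, in the range 650 nM to 2600 nM.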

Compound 4, concentration for 50% growth inhibition: 1360 nM
Beside the measured number, compound 4's estimate is 1.0-fold (0.02 log units) below it, and the stated range covers the measured number.
By their numbers in this assay, from the lowest: compounds 1, 3, 4 and 2 (each within the scatter of the next).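

In this assay, placing trifluoromethyl on an aromatic carbon of the terminal urea phenyl, meta to a trifluoromethyl group, gives a 1.0-fold lower number from compound 2 to compound 4 (0.01 log units; within the scatter), so this position takes a group of 4 heavy atoms in place of hydrogen without the two compounds being told apart. Within the data shown here, the same compound also gives the first single-place comparison at the oxygen on the aromatic ring: with the bis(trifluoromethyl)phenyl held constant, methyl in place of hydrogen on that oxygen gives a 1.1-fold higher number from compound 1 to compound 4 (0.04 log units; within the scatter), whereas compound 1 and compound 2 differ in more than one place and could not isolate this exchange. Compound 2, compound 3 and compound 4 now show three substitution patterns on the terminal phenyl of one shared core, all within the scatter of one another.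

The compounds shown leave open whether an amine or a carboxylic acid on this phenyl, or a longer chain than methyl on the oxygen, would separate from these values. No accompanying measurement bears on why these values lie so close together.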